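A few compounds are considered here, and "the series" means these few. Any claim that something is new, unique, unknown or untested is made for them only; others in the source may bear on it.

Working notes on the series, read in a functional assay on Caco-2 cells (Homo sapiens) for inhibition, read by sulforhodamine B assay, with a stated time of 48 h; on this read-out higher numbers stand for weaker inhibition and lower numbers for stronger inhibition. Compound 1 (`O=c1c([C@@H]2C[C@H](c3ccccc3)ON2c2ccccc2)coc2ccc(Br)cc12`) gives > 60000 nM, which is a limit of the assay and not a number. Compound 2 (`Cc1ccc2occ([C@@H]3[C@H]4C(=O)N(c5ccccc5)C(=O)[C@H]4ON3c3ccccc3)c(=O)c2c1`) gives > 60000 nM, also a limit. Compound 3 (`O=C1[C@H]2[C@H](ON(c3ccccc3)[C@@H]2c2coc3ccc(Br)cc3c2=O)C(=O)N1c1ccccc1`) gives a measured 20300 nM. Compound 1 therefore has no exact position, and the data show only (the limit of > 60000 nM in this assay, at which 2 of the 3 values shown sit).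

Compound 4 (`Cc1ccc2occ([C@@H]3C[C@H](c4ccccc4)ON3c3ccccc3)c(=O)c2c1`) differs from compound 1 at one place: methyl in place of bromo on an aromatic carbon. This is methyl in place of bromo on an aromatic carbon. Among the measured compounds shown here, the one measured step that bears on it runs the opposite way, bromo in place of methyl on an aromatic carbon, and shows an at least 2.9-fold lower number from compound 2 to compound 3 (0.47 log units; beyond the scatter). Reversed and carried over to the present pair, that step points to a higher number in this assay, or to no measurable change, since compound 1 already stands at a limit. One pair is thin support, and its size cannot be fixed exactly. The expected step is a step that the limit leaves unreadable from compound 1 to compound 4. A reported limit is the more likely result for the next measurement. For compound 4 the estimate is 100000 nM, with an expected range of 45000 nM to 300000 nM.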

Compound 4, half-maximal inhibitory concentration: 31700 nM
Estimate against measurement, compound 4: 3.2-fold (0.50 log units) above, and the stated range ends above it.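

In this assay, among the compounds shown here, methyl in place of bromo on this aromatic carbon gives an at least 1.8-fold lower number from compound 1 to compound 4 (0.27 log units; that floor lies within the scatter), so on the core of compound 1 the bromo group brings no gain, and the one earlier pair had pointed the other way. The direction of this change at this position is therefore not a fixed rule, since it reverses between the two cores: the same change on two cores in this assay, an at least 2.9-fold lower number (0.47 log units; beyond the scatter) from compound 2 to compound 3 and an at least 1.8-fold higher number (0.27 log units; that floor lies within the scatter) from compound 4 to compound 1, at least 5.5-fold (0.74 log units) apart, beyond the scatter of two such steps Compound 1 gives > 60000 nM, which remains a limit, so the step out of it has only a floor and its true size cannot be read: the limit of > 60000 nM in this assay, at which 2 of the 4 values shown sit.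

Each of the two steps starts from or ends at a limit, so how far apart the two cores truly lie remains known only as a minimum. Only bromo and methyl are shown on this aromatic carbon, so it remains open what a methoxy group, an amine or a carboxylic acid would do there, and whether either direction holds on any further core.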